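Indole nitrogen substitution in a Rho-kinase amide series

A few compounds are considered here, and "the series" means these few. Any claim that something is new, unique, unknown or untested is made for them only; others in the source may bear on it.

Compound 3 `COc1cccc(CNC(=O)c2cn(CCN(C)C)c3cc(-c4cn[nH]c4)ccc23)c1` sits at the low end of the two numbers reported in an assay on isolated protein for inhibition of Rho-associated protein kinase 1 (Homo sapiens) (on this read-out lower numbers stand for stronger inhibition and higher numbers for weaker inhibition), where compound 3 gives 5 nM. Compound 2 `COc1cccc(CN(CCCN(C)C)C(=O)c2cn(C)c3cc(-c4cn[nH]c4)ccc23)c1` gives 13 nM in this assay, the higher of the two numbers. Compound 1 `COc1cccc(CNC(=O)c2c[nH]c3cc(-c4cn[nH]c4)ccc23)c1` reaches the assay limit in this assay, giving < 1 nM, which is a limit rather than a number (the limit of < 1 nM in this assay, at which 1 of the 3 values shown sits). Among the measured compounds shown here, the single one-place step measured, an at least 5.0-fold higher number from compound 1 to compound 3 (0.69 log units; beyond the scatter), shows that placing a 2-(dimethylamino)ethyl group on the aromatic nitrogen of the shared core costs potency, though the size of that cost is only bounded on one side.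

Compound 4 `COc1cccc(CNC(=O)c2cn(-c3ccccc3)c3cc(-c4cn[nH]c4)ccc23)c1` follows from compound 3 by a single change: phenyl in place of 2-(dimethylamino)ethyl on an aromatic nitrogen. For the measured compounds named here, the step from compound 1 to compound 3 is the only measured step that bears on substitution at this nitrogen, and no measured pair tells how an aromatic group there compares with the 2-(dimethylamino)ethyl group. For compound 4 the number in this assay is therefore expected to stay on the weaker side of compound 1 and to move modestly upward from compound 3, a 3.0-fold higher number from compound 3 to compound 4 (0.48 log units; beyond the scatter), with wide uncertainty. The estimate for compound 4 in this assay is 15 nM, expected to lie between 4 nM and 60 nM.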

Compound 4, half-maximal inhibitory concentration: 21 nM
Beside the measured number, compound 4's estimate is 1.4-fold (0.15 log units) below it; the measured number falls inside the stated range.
By their numbers in this assay, from the lowest: compound 3; then compounds 2 and 4 (each within the scatter of the next). At a limit, below all of these: compound 1.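

The change from 2-(dimethylamino)ethyl to phenyl on this aromatic nitrogen gives a 4.2-fold higher number from compound 3 to compound 4 (0.62 log units; beyond the scatter), so in this assay the identity of the group matters here, not only whether the nitrogen is substituted. Phenyl in place of hydrogen gives an at least 21-fold higher number from compound 1 to compound 4 (1.32 log units; beyond the scatter), and with compound 3 and compound 4 both of the groups compared directly against hydrogen at this nitrogen, a chain with an amine and an aromatic ring of carbon only, move the number upward. Compound 1 stands at a limit, not a number, so this step and the earlier one from hydrogen are bounded on one side only: the limit of < 1 nM in this assay, at which 1 of the 4 values shown sits.

The pair of compound 3 and compound 4 changes the ring, the chain and the amine nitrogen together, so it does not separate which of these goes with the higher number. On these data alone, what a pyridine ring, a benzyl group or a simple methyl group on this nitrogen would give with the amide hydrogen kept remains open, as compound 2 differs from these compounds in more than one place.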